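Swapping Chloro for Methoxy on the Benzylidene Arm

The compounds below may be only part of what the source reports. "The series", "measured", "known", "first", "only" and "open" are said of these compounds alone.

Three compounds sharing one core were tested in a functional assay on HCT-116 cells (Homo sapiens) for cytotoxicity, read by MTT assay, with a stated time of 48 h; on this read-out higher numbers stand for weaker inhibition and lower numbers for stronger inhibition. Compound 1 `COc1ccc(/C=C2\N=C(c3ccc(C)cc3)N(C(=O)c3nc4c(c(C)nn4-c4ccccc4)c(=O)[nH]3)NC2=O)cc1` gives 37.7 nM. Compound 2 `Cc1nn(-c2ccccc2)c2nc(C(=O)N3NC(=O)/C(=C/c4ccccc4)N=C3c3ccc(Cl)cc3)[nH]c(=O)c12` gives 13.9 nM, and compound 3 `Cc1nn(-c2ccccc2)c2nc(C(=O)N3NC(=O)/C(=C/c4ccc(Cl)cc4)N=C3c3ccc(Cl)cc3)[nH]c(=O)c12` gives 15 nM. Among these numbers compound 3 stands second highest, within the scatter of compound 2 and furthest from compound 1. Among the compounds with values here, the single measured step, a 1.1-fold higher number from compound 2 to compound 3 (0.03 log units; within the scatter), lies within the scatter. Compound 4 `COc1ccc(/C=C2\N=C(c3ccc(Cl)cc3)N(C(=O)c3nc4c(c(C)nn4-c4ccccc4)c(=O)[nH]3)NC2=O)cc1` differs from compound 3 by methoxy in place of chloro on an aromatic carbon. Within the data shown here, no measured step tests this exact change; the only hint is that compound 1, which also carries a methoxy group, gives a higher number than compound 3. The expected step is therefore modest, a 1.7-fold higher number from compound 3 to compound 4 (0.22 log units; within the scatter), toward a higher number in this assay. Compound 4 is estimated at 25 nM, with a range from 10 nM to 60 nM.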

Compound 4, half-maximal inhibitory concentration: 12.9 nM
Compound 4: the middle estimate sits 1.9-fold (0.29 log units) above what was measured; the range from low to high includes it.
By their numbers in this assay, from the lowest: compounds 4, 2 and 3 (each within the scatter of the next); then compound 1.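

At this position on the benzylidene arm, hydrogen, chloro and methoxy cannot be told apart, since both a 1.2-fold lower number from compound 3 to compound 4 (0.07 log units; within the scatter) and a 1.1-fold lower number from compound 2 to compound 4 (0.03 log units; within the scatter) lie within the scatter. Within the data shown here, the only step beyond the scatter comes from a change on the other aromatic ring, chloro in place of methyl, with a 2.9-fold lower number from compound 1 to compound 4 (0.47 log units; beyond the scatter). No outside data are available to explain these results. Going by these compounds, whether an amine or a carboxylic acid at the benzylidene position would also stay within the scatter remains open.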